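Swapping hydroxymethyl for phenyl on a triple bond

The source may report more compounds than this note shows. Statements on the series, on what has been measured and on what is new or still open speak of the compounds shown alone.

- compound 1 `O=c1[nH]c(=O)n([C@H]2C[C@H](O)[C@@H](CO)O2)cc1/C=N/O`: 15500 nM
- compound 2 `C=Cc1cn([C@H]2C[C@H](O)[C@@H](CO)O2)c(=O)[nH]c1=O`: 14200 nM
- compound 3 `O=c1[nH]c(=O)n([C@H]2C[C@H](O)[C@@H](CO)O2)cc1C#CCO`: > 200000 nM

All three values come from an ADME assay on L1210/0 cells (Mus musculus) for cytotoxicity, with a stated time of 48 h; on this read-out higher numbers stand for weaker inhibition and lower numbers for stronger inhibition. Compound 3 stands at > 200000 nM, which is a limit and not a number.

Compound 4 `O=c1[nH]c(=O)n([C@H]2C[C@H](O)[C@@H](CO)O2)cc1C#Cc1ccccc1` has not yet been measured. It differs from compound 3 as follows: phenyl in place of hydroxymethyl on a triple-bonded carbon.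

Within the data shown here, three measured steps bear on this change. The first, a 1.1-fold lower number from compound 1 to compound 2 (0.04 log units; within the scatter), shows no real difference. The other two are large: an at least 12-fold higher number from compound 1 to compound 3 (1.11 log units; beyond the scatter), and an at least 14-fold higher number from compound 2 to compound 3 (1.14 log units; beyond the scatter). Among the measured compounds shown here, both of these large steps lead to the only measured compound that carries hydroxymethyl, so a sizeable move is expected once that group leaves. The expected direction is toward compound 1 and compound 2, given the size of an at least 14-fold higher number from compound 2 to compound 3 (1.14 log units; beyond the scatter). Phenyl appears in no measured compound, however, so the size of the move remains uncertain, and a full return is not assumed.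

The expected change, toward a lower number and so stronger inhibition, is an at least 4.0-fold lower number from compound 3 to compound 4 (0.60 log units; beyond the scatter). For compound 4 the estimated value is 50000 nM, with an expected range from 10000 nM to 200000 nM.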

Compound 4, half-maximal inhibitory concentration: > 200000 nM
Compound 4 gave a limit, no number; the forecaster's own chance of this, stated with the estimate: 30%; middle value at least 4.0-fold (0.60 log units) away from the limit.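

Before this result, hydroxymethyl was the only group on the triple-bonded carbon, so the high number of compound 3 could have belonged to that one group. Compound 4 carries phenyl there, with none of the hydrogen-bond donors or acceptors of hydroxymethyl, and it still lies far from the compounds without a triple bond, with an at least 14-fold higher number from compound 2 to compound 4 (1.14 log units; beyond the scatter) and an at least 12-fold higher number from compound 1 to compound 4 (1.11 log units; beyond the scatter). The expected return toward those compounds therefore does not appear, and the high number now goes with two quite different groups on the triple-bonded carbon rather than with hydroxymethyl alone.

The step between compound 3 and compound 4 cannot be read, because each of the two values is a limit and not a number: the limit of > 200000 nM in this assay, at which 2 of the 4 values shown sit.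

So it remains open how far apart compound 3 and compound 4 truly are, and whether either one has any measurable effect on these cells. On these data alone, it also remains open whether an amine or a longer chain on the triple-bonded carbon would bring the number down, or whether every group at this place would stay at the limit.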